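Swapping a fluorinated benzyl arm for a methylated one

The source may report more compounds than this note shows. Statements on the series, on what has been measured and on what is new or still open speak of the compounds shown alone.

Compound 1, `CCN(C)C(=O)N1CCN(C(=S)SCc2cn(Cc3ccccc3F)nn2)CC1`, carries a 2-fluorobenzyl group on the shared core. For the measured compounds named here, in a functional assay on SMMC-7721 cells (Homo sapiens) for cytotoxicity, read by MTT assay, with a stated time of 72 h (a lower number here means a stronger inhibitor, a higher number a weaker inhibitor), compound 1 gives 19700 nM, and this is the only plain number in the set. Compound 2, `O=C(NC1CCCCC1)N1CCN(C(=S)SCc2cn(Cc3ccccc3F)nn2)CC1`, differs from compound 1 only in the group on the carbonyl carbon. In this assay compound 2 gives > 128000 nM, which is a limit of the assay rather than a number. Going by the values given here, the one measured step, an at least 6.4-fold higher number from compound 1 to compound 2 (0.81 log units; beyond the scatter), therefore rests at one end on (the limit of > 128000 nM in this assay, at which 1 of the 2 values shown sits).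

Compound 3, `CCN(C)C(=O)N1CCN(C(=S)SCc2cn(Cc3ccc(C)cc3)nn2)CC1`, is the compound still to be measured. It differs from compound 1 by 4-methylphenyl in place of 2-fluorophenyl on a saturated chain carbon bound to an aromatic nitrogen. The measured step from compound 1 to compound 2 alters a different part of the molecule, the group on the carbonyl carbon, so it offers no direct guidance on changing the benzyl arm. Among the compounds with values here, with no measured step touching this position, no change beyond the scatter is expected, and the estimated step of a 1.0-fold higher number from compound 1 to compound 3 (0.01 log units; within the scatter) is close to none. Compound 3 is therefore expected to give about 20000 nM in this assay, within a range from 7000 nM to 60000 nM.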

Compound 3, half-maximal inhibitory concentration: > 128000 nM
Compound 3: no number, only a limit; the forecaster's own chance of this, stated with the estimate: 20%; at least 6.4-fold (0.80 log units) between middle value and limit.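

The benzyl arm, which the earlier step left untouched, proves sensitive to a single change in this assay: going from 2-fluorobenzyl to 4-methylbenzyl gives an at least 6.4-fold higher number from compound 1 to compound 3 (0.81 log units; beyond the scatter), so this is a weaker inhibitor and the arm cannot be swapped freely. Among the compounds shown, both single changes to compound 1, one on the carbonyl carbon and one on the benzyl arm, now lead to a limit of the assay and not to a number, leaving compound 1 as the only compound with a plain value. The true size of the new step stays unknown, and it can only be read as a minimum, because one of its ends is such a limit: the limit of > 128000 nM in this assay, at which 2 of the 3 values shown sit.

The swap removes the fluorine and adds the methyl in one move, so the compounds shown cannot say which of the two matters; a plain benzyl group or a 4-fluorobenzyl group would separate them. They also leave open whether any other group on this arm, such as 2-chlorobenzyl, would give a lower number than compound 1.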